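Swapping a Benzyl for a Methoxy Chain: Cytotoxicity Outlook

The source may hold more compounds than are shown below. What is called first, only, known or untested is meant among the compounds shown, and "the series" means these compounds.

Of the compounds shown here, two of one family have been tested so far in an ADME assay on 2209-23 cells (Homo sapiens) for cytotoxicity, read by WST assay; a lower number here means that less compound is tolerated, a higher number that more compound is tolerated. Compound 1 `CS(=O)(=O)Nc1ccc2c(c1)S(=O)(=O)C=C(c1c(O)c3cc(Cl)ccc3n(Cc3ccc(F)cc3)c1=O)N2` and compound 2 `CS(=O)(=O)Nc1ccc2c(c1)S(=O)(=O)C=C(c1c(O)c3cc(F)ccc3n(Cc3ccccc3)c1=O)N2` share a common core and differ from each other at two places. In this assay compound 1 reaches only the limit of > 50000 nM, a bound of the measurement rather than a number. Compound 2 likewise stops at the limit of > 50000 nM, again a bound and not a number. Compound 2 therefore stands exactly where every value known here stands: the limit of > 50000 nM in this assay, at which 2 of the 2 values shown sit. The two compounds cannot be ordered against each other on these numbers.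

Compound 3 `COC(C)(C)CCn1c(=O)c(C2=CS(=O)(=O)c3cc(NS(C)(=O)=O)ccc3N2)c(O)c2cc(F)ccc21` has not yet been measured. It is built from compound 2 by one change: 2-methoxy-2-methylpropyl in place of phenyl on a saturated chain carbon bound to an aromatic nitrogen. Among the compounds with values here, no measured pair shows what this kind of change does in this assay. Since compound 2 sits at the limit, the step from compound 2 to compound 3 is expected to be none beyond the usual scatter, a number no higher from compound 2 to compound 3 (the limit leaves the size open). Compound 3 is thus estimated at 50000 nM, within a range from 20000 nM to 150000 nM.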

Compound 3, half-maximal cytotoxic concentration: > 50000 nM
Compound 3: a limit, no number; the forecaster's own chance of this, stated with the estimate: 75%; the middle value sits exactly at the limit.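

In this assay compound 3 gives > 50000 nM, a limit and not a number. Within the data shown here, compound 2 also stands at a limit, so no step from compound 2 to compound 3 can be read. All three compounds share one reading: the limit of > 50000 nM in this assay, at which 3 of the 3 values shown sit. The compounds shown leave open how much of each the cells tolerate, and whether 2-methoxy-2-methylpropyl in place of phenyl changes that at all.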